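A few compounds are considered here, and "the series" means these few. Any claim that something is new, unique, unknown or untested is made for them only; others in the source may bear on it.

Compound 1 `COc1ccc(C(=O)n2c(-c3cn(C)c4ccccc34)nc3ccccc32)cc1OC` is taken as the point of departure, and in a functional assay on A549 cells (Homo sapiens) for inhibition, read by MTT assay, with a stated time of 24 h (a higher number here means a weaker inhibitor of growth, a lower number a stronger inhibitor of growth), compound 1 gives 3100 nM. Compound 2 `Cn1cc(-c2nc3ccccc3n2C(=O)c2ccccc2Br)c2ccccc21` differs from it by the exchange 2-bromophenyl in place of 3,4-dimethoxyphenyl on a carbonyl carbon and gives 43200 nM in this assay, so the step of a 14-fold higher number from compound 1 to compound 2 (1.14 log units; beyond the scatter) is a large one. Compound 3 `COc1ccc(C(=O)n2c(-c3cn(C)c4ccc(Br)cc34)nc3ccccc32)cc1OC` carries a different core, the two cores differing by bromo in place of hydrogen on an aromatic carbon, and in this assay compound 3 gives 3400 nM, the step of a 1.1-fold higher number from compound 1 to compound 3 (0.04 log units; within the scatter) being small. Compound 4 `Cn1cc(-c2nc3ccccc3n2C(=O)c2ccccc2Br)c2cc(Br)ccc21` has not yet been measured; it stands to compound 3 as compound 2 stands to compound 1, through the same change (2-bromophenyl in place of 3,4-dimethoxyphenyl on a carbonyl carbon). Because the step of a 14-fold higher number from compound 1 to compound 2 (1.14 log units; beyond the scatter) was large and the step of a 1.1-fold higher number from compound 1 to compound 3 (0.04 log units; within the scatter) was small, a step of similar size is expected in this assay, namely a 14-fold higher number from compound 3 to compound 4 (1.14 log units; beyond the scatter). Compound 4 is therefore estimated to give 47000 nM in this assay, with an expected range from 20000 nM to 110000 nM.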

Compound 4, concentration for 50% growth inhibition: 46700 nM
Compound 4: the middle estimate sits 1.0-fold (0.00 log units) above what was measured; the measured number falls inside the stated range.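

In this assay, the exchange of 3,4-dimethoxyphenyl for 2-bromophenyl on the carbonyl carbon gave a 14-fold higher number from compound 3 to compound 4 (1.14 log units; beyond the scatter) on the bromo-bearing core, matching its step on the core of compound 1: the same change on two cores in this assay, a 14-fold higher number (1.14 log units; beyond the scatter) from compound 1 to compound 2 and a 14-fold higher number (1.14 log units; beyond the scatter) from compound 3 to compound 4, 1.0-fold (0.01 log units) apart, within the scatter of two such steps. The bromo in place of hydrogen stayed small with 2-bromophenyl on the carbonyl carbon, giving a 1.1-fold higher number from compound 2 to compound 4 (0.03 log units; within the scatter) and matching its earlier step: the same change on two cores in this assay, a 1.1-fold higher number (0.04 log units; within the scatter) from compound 1 to compound 3 and a 1.1-fold higher number (0.03 log units; within the scatter) from compound 2 to compound 4, 1.0-fold (0.01 log units) apart, within the scatter of two such steps. This shows that both changes carried over within these compounds, but only between two cores that differ by one bromo, and it does not show that the exchange would carry over to a more distant core.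

The exchange removes the methoxy groups and brings in bromine in a single step, so the compounds shown do not separate these two parts. On these data alone, it also remains open how an amine or a carboxylic acid on the phenyl ring, or a longer chain in place of the methyl group, would behave.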